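Pyridin-4-yl for phenyl on a ghrelin receptor agonist sulfonamide

The source may hold more compounds than are shown below. What is called first, only, known or untested is meant among the compounds shown, and "the series" means these compounds.

Measured compounds: compound 1 `C[C@@H]1CN(c2ccc(Cl)c(NS(=O)(=O)c3ccc(-c4ccccn4)s3)c2)C[C@H](C)N1` with 39.8 nM; compound 2 `COc1ccc(N2C[C@@H](C)N[C@@H](C)C2)cc1NS(=O)(=O)c1ccc(-c2ccccc2)cc1` with 6.31 nM; compound 3 `COc1ccc(N2C[C@@H](C)N[C@@H](C)C2)cc1NS(=O)(=O)c1ccc(-c2cnco2)s1` with 2.51 nM.

In a functional assay for agonist activity at growth hormone secretagogue receptor type 1 (Homo sapiens), read by FLIPR (on this read-out lower numbers stand for an effect already at smaller amounts and higher numbers for an effect only at larger amounts of compound), compound 2 gives 6.31 nM, the second highest number of the three, with compound 3 nearest and compound 1 furthest away. Compound 4 `COc1ccc(N2C[C@@H](C)N[C@@H](C)C2)cc1NS(=O)(=O)c1ccc(-c2ccncc2)cc1` differs from compound 2 in one place: pyridin-4-yl in place of phenyl on an aromatic carbon. For the measured compounds named here, no pair among the measured compounds shows this change alone, so the size of the step is not known from these data. The study expects the step from compound 2 to compound 4 in this assay to be small, with no clear direction and probably not beyond the scatter, giving a 1.3-fold higher number from compound 2 to compound 4 (0.10 log units; within the scatter). For compound 4 the estimate is 8 nM, ranging from 2.5 nM to 25 nM.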

Compound 4, half-maximal effective concentration: 316 nM
The estimate for compound 4 lay 40-fold (1.60 log units) below the measured number; measured number above the stated range.
By their numbers in this assay, from the lowest: compound 3; then compound 2; then compound 1; then compound 4.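

In this assay, pyridin-4-yl in place of phenyl gives a 50-fold higher number from compound 2 to compound 4 (1.70 log units; beyond the scatter), so this position, para to a large group, separates two six-membered aromatic rings with the same count of heavy atoms. The earlier compounds shown here held no pair that showed this change alone, and this step gives the first measure of its size and direction. Nothing available here accounts for the step.

On these data alone, what pyridin-3-yl or 4-fluorophenyl would do at this position remains open. Also open, as far as these compounds go, is whether the same change would give a similar step on the core of compound 3.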